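The source may hold more compounds than are shown below. What is called first, only, known or untested is meant among the compounds shown, and "the series" means these compounds.

In an ADME assay on HEK293 cells (Homo sapiens) for cytotoxicity, read by fluorescence and resazurin assay, with a stated time of 24 h (a higher number here means that more compound is tolerated, a lower number that less compound is tolerated), compound 1 `COc1ccccc1-c1nnc(SC2=CS(=O)(=O)c3ccccc32)o1` gives 3000 nM, compound 2 `COc1ccc(-c2nnc(SC3=CS(=O)(=O)c4ccccc43)o2)cc1` gives 2000 nM and compound 3 `O=S1(=O)C=C(Sc2nnc(-c3ccccn3)o2)c2ccccc21` gives 5000 nM. Compound 3 thus stands apart from compound 2 but not from compound 1. Compound 4 `O=S1(=O)C=C(Sc2nnc(-c3cccc(Cl)c3)o2)c2ccccc21` has 3-chlorophenyl in place of pyridin-2-yl on an aromatic carbon. Within the data shown here, no chlorophenyl compound has been measured, so the closest evidence is the two steps that put pyridin-2-yl in place of a methoxyphenyl: a 1.7-fold higher number from compound 1 to compound 3 (0.22 log units; within the scatter) and a 2.5-fold higher number from compound 2 to compound 3 (0.40 log units; beyond the scatter). Read in reverse, they suggest a small fall in this assay, close to the edge of the scatter. The expected step is a 2.0-fold lower number from compound 3 to compound 4 (0.30 log units; within the scatter). The estimated value for compound 4 is 2500 nM, with an expected range from 1000 nM to 6000 nM.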

Compound 4, half-maximal cytotoxic concentration: 6000 nM
For compound 4 the middle estimate is 2.4-fold (0.38 log units) below the measured one; the measured number falls inside the stated range.
By their numbers in this assay, from the lowest: compounds 2, 1, 3 and 4 (each within the scatter of the next, the first and the last beyond it).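

In this assay, replacing pyridin-2-yl with 3-chlorophenyl gives no change beyond the scatter (a 1.2-fold higher number from compound 3 to compound 4 (0.08 log units; within the scatter)), so at this position a ring of carbon only, with no hydrogen-bond acceptor, reads like the pyridine. Among these compounds, compound 4 stands apart from the 4-methoxyphenyl compound (a 3.0-fold higher number from compound 2 to compound 4 (0.48 log units; beyond the scatter)) but not from the 2-methoxyphenyl compound (a 2.0-fold higher number from compound 1 to compound 4 (0.30 log units; within the scatter)), which leaves compound 2 as the only separated member of the comparison. Nothing available explains these results. On these data alone, whether an amine or a carboxylic acid on this aryl ring would shift the number remains open, as does the effect of a saturated ring such as morpholine at this position.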